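A few compounds are considered here, and "the series" means these few. Any claim that something is new, unique, unknown or untested is made for them only; others in the source may bear on it.

Working notes on the series. In an ADME assay on the whole organism (Mus musculus, strain ICR) for pharmacokinetics, at a dose of 50 mg/kg by the oral route (on this read-out higher numbers stand for higher exposure at the dose given and lower numbers for lower exposure), compound 2 (`N#CC1CC(=O)N(c2cnn3c2CN(C(=O)Nc2cc(F)c(F)c(F)c2)C(C2CC2)C3)C1`) gives 14400 nM and sits level, within the scatter, with compound 1 (`O=C1CC(Oc2ncccn2)CN1c1cnn2c1CN(C(=O)Nc1cc(F)c(F)c(F)c1)C(C1CC1)C2`) at 10300 nM on the same read-out. Compound 3 (`C[C@H]1Cn2ncc(N3CC(c4ccccc4)CC3=O)c2CN1C(=O)Nc1cc(F)c(F)c(F)c1`) gives 6670 nM and lies beyond the scatter on the low side of compound 2, but its core differs, so it serves only as a loose guide.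

The next compound is compound 4 (`O=C1CC(c2ncccn2)CN1c1cnn2c1CN(C(=O)Nc1cc(F)c(F)c(F)c1)C(C1CC1)C2`), with pyrimidin-2-yl in place of cyano on a saturated ring carbon. Among the compounds with values here, the one measured step that bears on this change is a 1.4-fold higher number from compound 1 to compound 2 (0.15 log units; within the scatter) and it comes from cyano in place of (pyrimidin-2-yl)oxy on the same kind of carbon. Within the data shown here, that step is small and stays within the scatter, and no measured step covers the direct attachment of pyrimidin-2-yl.

Compound 3 also carries a six-membered aromatic ring on a saturated ring carbon, which gives a slight lean to the low side. The expected change is therefore small, with a 1.5-fold lower number from compound 2 to compound 4 (0.18 log units; within the scatter) as the estimated step. In this assay the estimate for compound 4 is 9500 nM with an expected range from 4500 nM to 19000 nM for repeated measurements.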

Compound 4, maximal plasma concentration: 12000 nM
Compound 4: middle estimate off by 1.3-fold (0.10 log units), on the low side; measured number inside the range.
By their numbers in this assay, from the lowest: compounds 3, 1, 4 and 2 (each within the scatter of the next, the first and the last beyond it).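

In this assay, directly attached pyrimidin-2-yl at this saturated ring carbon gives a 1.2-fold lower number from compound 2 to compound 4 (0.08 log units; within the scatter), so replacing cyano with this much larger group, which brings a six-membered aromatic ring, produces no change beyond the scatter. The comparison with the oxygen-linked group gives a 1.2-fold higher number from compound 1 to compound 4 (0.07 log units; within the scatter), which shows that pyrimidin-2-yl and (pyrimidin-2-yl)oxy also stand level at this position on the shared core. Cyano, pyrimidin-2-yl and (pyrimidin-2-yl)oxy are therefore not separated on this read-out, while no measurement at hand accounts for this level behaviour.

The compounds shown leave open how an amine or a carboxylic acid at this carbon would read in this assay, as all three groups compared here carry no net charge. Also open, as far as these compounds go, is whether phenyl at this position on the same shared core would stay level with these groups, as the phenyl-bearing compound 3 has a different core and cannot settle that comparison.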